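Ethyl Ester of a Bicyclic Acid: Expected Potency

The source may hold more compounds than are shown below. What is called first, only, known or untested is meant among the compounds shown, and "the series" means these compounds.

compound 1, `CCCSc1nc(Cl)c2c(n1)N(Cc1ccccc1)C(C(=O)N1CCN(C(=O)OC(C)(C)C)CC1)N2`: 31200 nM
compound 2, `CCCSc1nc(Cl)c2c(n1)N(Cc1ccccc1)C(C(=O)O)N2`: > 64000 nM

In a functional assay on TE-1 cells (Homo sapiens) for antiproliferative activity, read by MTT assay, with a stated time of 72 h (on this read-out higher numbers stand for weaker inhibition and lower numbers for stronger inhibition), compound 1 gives 31200 nM. For compound 2 this assay reports only a limit, > 64000 nM, and this reading is recorded as the limit of > 64000 nM in this assay, at which 1 of the 2 values shown sits. Compound 2 therefore stands at the weak end of what the assay can read.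

Compound 3, `CCCSc1nc(Cl)c2c(n1)N(Cc1ccccc1)C(C(=O)OCC)N2`, differs from compound 2 by ethyl in place of hydrogen on an oxygen next to a carbonyl group. Among the compounds with values here, no measured pair shows this change, so the step it means is expected to be an at least 1.4-fold lower number from compound 2 to compound 3 (0.15 log units; that floor lies within the scatter), modest and, if anything, toward stronger inhibition. Compound 3 is estimated at 45000 nM, expected to fall between 15000 nM and 120000 nM.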

Compound 3, half-maximal inhibitory concentration: > 64000 nM
Compound 3: no number, only a limit; the forecaster's own chance of this, stated with the estimate: 45%; middle value at least 1.4-fold (0.15 log units) away from the limit.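

In this assay no step can be read from compound 2 to compound 3, because both give a limit rather than a number: the limit of > 64000 nM in this assay, at which 2 of the 3 values shown sit.

As far as these compounds go, whether changing carboxy to ethoxycarbonyl alters inhibition at all stays open.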